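Acetamido for Methylsulfonyl: Estimating an Agonist Analogue

The source may hold more compounds than are shown below. What is called first, only, known or untested is meant among the compounds shown, and "the series" means these compounds.

Compound 1 `CNc1nc(NCC(C)(C)C)cc(-c2ccccn2)n1` gives 73 nM
Compound 2 `CNc1nc(NCc2ccc(S(C)(=O)=O)cc2)cc(-c2ccccn2)n1` gives 36 nM

In a functional assay on HEK293 cells for agonist activity at G-protein coupled receptor 39 (Homo sapiens), read by inositol phosphate accumulation (on this read-out higher numbers stand for an effect only at larger amounts of compound and lower numbers for an effect already at smaller amounts), compound 2 gives the lower of the two numbers; compound 1 gives a higher one, and that gap lies beyond the usual scatter. Compound 3 `CNc1nc(NCc2ccc(NC(C)=O)cc2)cc(-c2ccccn2)n1` differs from compound 2 by acetamido in place of methylsulfonyl on an aromatic carbon. Going by the values given here, no measured pair shows this exact change, so there is no measured step to lean on. A small shift is expected, so the step from compound 2 to compound 3 is estimated as a 1.4-fold higher number from compound 2 to compound 3 (0.14 log units; within the scatter), quite possibly none beyond the scatter. Compound 3 is therefore expected to give about 50 nM, with a range from 18 nM to 140 nM.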

Compound 3, half-maximal effective concentration: 5 nM
Compound 3: the middle estimate sits 10-fold (1.00 log units) above what was measured, and the stated range ends above it.
By their numbers in this assay, from the lowest: compound 3; then compound 2; then compound 1.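

In this assay, placing acetamido instead of methylsulfonyl on the aromatic carbon para to a large group gives a 7.2-fold lower number from compound 2 to compound 3 (0.86 log units; beyond the scatter), so the number depends on which group sits at this position. The two groups have the same heavy-atom count, but only acetamido carries a hydrogen-bond donor. No evidence here shows what produces this shift.

As far as these compounds go, whether an amine or a carboxylic acid at this position would give a similar number remains open. So does whether acetamido would have the same effect on a different core.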